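The source may hold more compounds than are shown below. What is called first, only, known or untested is meant among the compounds shown, and "the series" means these compounds.

Measured so far in an ADME assay on HepG2 cells (Homo sapiens) for cytotoxicity, read by MTT assay, with a stated time of 72 h; on this read-out lower numbers stand for higher toxicity in this test and higher numbers for lower toxicity in this test:
Compound 1 `Nc1ccc(C#Cc2cc(Cl)cn3c([N+](=O)[O-])c(CS(=O)(=O)c4ccccc4)nc23)cc1`: > 3900 nM
Compound 2 `CC(O)(C#Cc1cc(Cl)cn2c([N+](=O)[O-])c(CS(=O)(=O)c3ccccc3)nc12)c1ccccc1`: 18800 nM

Among the measured compounds shown here, compound 2 gives 18800 nM, the only true number in this small set. Compound 1 gives only a limit of the assay, not a number: the limit of > 3900 nM in this assay, at which 1 of the 2 values shown sits. So compound 2 cannot yet be ranked against anything.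

Compound 3 `CC(C)(O)C#Cc1cc(Cl)cn2c([N+](=O)[O-])c(CS(=O)(=O)c3ccccc3)nc12` has not been measured. It differs from compound 2 in one place, with methyl in place of phenyl on a saturated chain carbon bound to an oxygen on a saturated carbon, a saturated chain carbon and a triple-bonded carbon. The 3-hydroxy-3-phenylbut-1-yn-1-yl group thus becomes 3-hydroxy-3-methylbut-1-yn-1-yl: methyl in place of phenyl on a saturated chain carbon bound to an oxygen on a saturated carbon, a saturated chain carbon and a triple-bonded carbon.

For the measured compounds named here, the one measured step that bears on this change is a step that the limit leaves unreadable from compound 1 to compound 2. Its size cannot be read, so it offers no guide to size or direction. With nothing firmer to go on, the expected 1.2-fold higher number from compound 2 to compound 3 (0.07 log units; within the scatter) stays within the usual scatter in this assay, with no direction expected. For compound 3 the estimated value is 22000 nM, with an expected range from 7000 nM to 70000 nM.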

Compound 3, half-maximal cytotoxic concentration: > 62500 nM
Compound 3: a limit, no number (the forecaster's own chance of this, stated with the estimate: 35%); middle value at least 2.8-fold (0.45 log units) from the limit.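

In this assay, among the compounds shown here, the change of phenyl to methyl on this saturated chain carbon gives the first step in the set whose size can be read: an at least 3.3-fold higher number from compound 2 to compound 3 (0.52 log units; beyond the scatter). With the hydroxy group, the triple bond and the shared core all unchanged, the 3-hydroxy-3-methylbut-1-yn-1-yl group therefore goes with lower toxicity in this test than the 3-hydroxy-3-phenylbut-1-yn-1-yl group, so the group carried on this carbon does matter for this read-out. Compound 3 gives a limit, not a number: the limit of > 62500 nM in this assay, at which 1 of the 3 values shown sits.

The steps that start from compound 1 cannot be read, so the 4-aminophenyl group cannot be placed against either of the two hydroxy-bearing groups. On these data alone, it also remains open whether the difference follows the aromatic ring itself or simply the number of carbons in the group, and an ethyl or a cyclohexyl group in place of methyl on the same carbon would help to separate these two readings.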